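Sulfonamide series: fluorophenyl replacement for dimethylphenyl

The source may report more compounds than this note shows. Statements on the series, on what has been measured and on what is new or still open speak of the compounds shown alone.

Measured so far:
compound 1 `CCCCOc1ccc(NS(=O)(=O)c2ccc(N3CCNC3=O)cc2)cc1`; in a functional assay on M21 cells (Homo sapiens) for antiproliferative activity, read by sulforhodamine B assay, with a stated time of 48 h (on this read-out lower numbers stand for stronger inhibition and higher numbers for weaker inhibition), compound 1 gives 580 nM
compound 2 `Cc1cc(C)cc(NS(=O)(=O)c2ccc(N3CCNC3=O)cc2)c1`; in this assay compound 2 gives 63 nM

Compound 2 holds the lower of the two numbers in this assay, and its gap to compound 1 lies beyond the scatter. Compound 3 `O=C1NCCN1c1ccc(S(=O)(=O)Nc2ccc(F)cc2)cc1` differs from compound 2 in one place: 4-fluorophenyl in place of 3,5-dimethylphenyl on a sulfonamide nitrogen. Going by the values given here, with only two measured points, no step of this kind has been seen; the number for compound 3 is nonetheless expected to rise, a step of a 3.2-fold higher number from compound 2 to compound 3 (0.50 log units; beyond the scatter) expected to lie beyond the scatter, though not to reach the weakness of compound 1. Compound 3 is estimated at 200 nM, with a range from 50 nM to 800 nM.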

Compound 3, half-maximal inhibitory concentration: 230 nM
For compound 3 the middle estimate is 1.2-fold (0.06 log units) below the measured one; measured number inside the range.
By their numbers in this assay, from the lowest: compound 2; then compound 3; then compound 1.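

In this assay the aryl group on the sulfonamide nitrogen now has a measured step: 4-fluorophenyl in place of 3,5-dimethylphenyl gives a 3.7-fold higher number from compound 2 to compound 3 (0.56 log units; beyond the scatter) and so costs potency. Fluoro in place of butoxy on an aromatic carbon gives a 2.5-fold lower number from compound 1 to compound 3 (0.40 log units; beyond the scatter) in the opposite direction, which places compound 3 as an intermediate on both steps. Nothing available explains the size of either step. Still open, as far as these compounds go, is whether 3,5-difluorophenyl on this nitrogen would behave like 3,5-dimethylphenyl or like 4-fluorophenyl. From the compounds shown here alone, an amine or a carboxylic acid on this ring also remains untested against fluoro.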